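Lengthening a Sulfur-Bound Chain in Cytotoxicity Testing

The source may report more compounds than this note shows. Statements on the series, on what has been measured and on what is new or still open speak of the compounds shown alone.

Compound 1 `CCCCSC(=S)N[C@H]1CCOC1=O`: > 128000 nM (a limit of the assay)
Compound 2 `CCCCCCCCSC(=S)N[C@H]1CCOC1=O`: > 128000 nM (a limit of the assay)

In a functional assay on MCF7 cells (Homo sapiens) for cytotoxicity, read by MTT assay, with a stated time of 72 h (a higher number here means a weaker inhibitor, a lower number a stronger inhibitor), compound 1 gives > 128000 nM, which is a limit of the assay rather than a number. In the same way, in this assay compound 2 gives > 128000 nM, again a limit and not a measured number. The step that the two limits leave unreadable from compound 1 to compound 2 therefore cannot be read, since (the limit of > 128000 nM in this assay, at which 2 of the 2 values shown sit). Compound 2 thus stands only at a limit, with no value of its own.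

Compound 3 `CCCCCCCCCCCCCCSC(=S)N[C@H]1CCOC1=O` differs from compound 2 by hexyl in place of hydrogen on a saturated chain carbon, eight bonds along the chain from a sulfur. For the measured compounds named here, the only measured step that bears on this change is a step that the two limits leave unreadable from compound 1 to compound 2, and the two limits leave its size unknown. Going by the values given here, no step of readable size is at hand. Compound 3 is therefore expected to sit at the same limit, and the expected step is a step that the limit leaves unreadable from compound 2 to compound 3, nothing beyond the scatter. The estimate for compound 3 in this assay is 200000 nM, within a range from 60000 nM to 700000 nM.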

Compound 3, half-maximal inhibitory concentration: 30500 nM
Compound 3: middle estimate off by 6.6-fold (0.82 log units), on the high side; the measured number lies below the stated range.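

Hexyl in place of hydrogen on a saturated chain carbon, eight bonds along the chain from a sulfur, gives the first change that can be read in this series: in this assay there is an at least 4.1-fold lower number from compound 2 to compound 3 (0.62 log units; beyond the scatter). So lengthening this chain can move the number, which the earlier pair could not show, and the true size of the step may be larger than the printed one. Compound 3 is the only one of the three with a measured number, while the other two stand at a limit and not at a number: the limit of > 128000 nM in this assay, at which 2 of the 3 values shown sit.

On these data alone, whether a longer chain would lower the number further, or lose the gain, stays open. So does whether a chain carrying an amine or a carboxylic acid would behave like the plain hydrocarbon chain of compound 3.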